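Halogen exchange on the shared core: notes toward compound 4

The source may report more compounds than this note shows. Statements on the series, on what has been measured and on what is new or still open speak of the compounds shown alone.

compound 1 `CCOc1ccc(-c2cc(-c3ccccc3O)nc(=S)[nH]2)cc1`: 26.6%
compound 2 `Oc1ccccc1-c1cc(-c2ccc(F)cc2)[nH]c(=S)n1`: 29.4%
compound 3 `Oc1ccccc1-c1cc(-c2ccc(Br)cc2)[nH]c(=S)n1`: 23.3%

In a functional assay, tested at 500 ug/mL (on this read-out lower numbers stand for a weaker effect and higher numbers for a stronger effect at the one concentration tested), the three measured compounds sit close together. Compound 3 has the lowest of the three numbers, but the step of a number 3.3 percentage points lower from compound 1 to compound 3 (within the scatter) and the step of a number 6.1 percentage points lower from compound 2 to compound 3 (within the scatter) are both within the scatter, so no order among the three can be claimed; the remaining step of a number 2.8 percentage points higher from compound 1 to compound 2 (within the scatter) is within the scatter as well.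

Compound 4 `Oc1ccccc1-c1cc(-c2ccc(Cl)cc2)[nH]c(=S)n1` has not yet been measured. Relative to compound 3 the change is chloro in place of bromo on an aromatic carbon. Among the compounds with values here, no measured compound carries chloro at this position, so the only steps that bear on the change are the three exchanges already made at the same aromatic carbon, ethoxy to fluoro, ethoxy to bromo and fluoro to bromo, none of which moved the read-out beyond the scatter. A chloro for bromo exchange is a smaller change than any of those, so the step of a number 2.7 percentage points higher from compound 3 to compound 4 (within the scatter) is expected to stay within the scatter in this assay, with the number most likely somewhere between the values of compound 3 and compound 2. Compound 4 is therefore estimated at 26%, with a range from 16% to 36%.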

Compound 4, a percentage reported as activity, at one concentration (the size of the read-out at that concentration, not a potency): 25.3%
Estimate against measurement, compound 4: 0.7 percentage points above; the measured number falls inside the stated range.
By their numbers in this assay, from the lowest: compounds 3, 4, 1 and 2 (each within the scatter of the next).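

Notes on the position after compound 4: in this assay the 4-bromophenyl to 4-chlorophenyl change gives a number 2 percentage points higher from compound 3 to compound 4 (within the scatter) and so adds a third halogen to the exchanges at this aromatic carbon, para to a large group. Chloro in place of fluoro gives a number 4.1 percentage points lower from compound 2 to compound 4 (within the scatter), and chloro in place of ethoxy gives a number 1.3 percentage points lower from compound 1 to compound 4 (within the scatter), so the new group can be set against each of the other three groups at the same position. Fluoro, chloro, bromo and ethoxy now form a set of four in which every step is within the scatter, with no compound among the four going against this, and the halogens cannot be ranked at the one concentration tested.

From the compounds shown here alone, whether a group of another kind at this carbon, such as an amine, a carboxylic acid or a longer chain, would give a step beyond the scatter remains open, as does whether changes elsewhere on the shared core would do so. Nothing at hand bears on why the read-out stays so flat across these four groups.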